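The source may report more compounds than this note shows. Statements on the series, on what has been measured and on what is new or still open speak of the compounds shown alone.

Measured so far in a functional assay on A549 cells (Homo sapiens) for antiproliferative activity, read by MTT assay, with a stated time of 48 h; a higher number here means a weaker inhibitor, a lower number a stronger inhibitor:
compound 1 `N#CC1=C(N)Oc2c(c3nc4ccccc4nc3c3ccccc23)C12C(=O)N(Cc1cnnn1-c1ccccc1Br)c1ccccc12`: > 50000 nM, a limit of the assay.
compound 2 `Cc1ccc(-n2nncc2CN2C(=O)C3(C(C#N)=C(N)Oc4c3c3nc5ccccc5nc3c3ccccc43)c3ccccc32)cc1C`: > 50000 nM, also a limit of the assay.
compound 3 `N#CC1=C(N)Oc2c(N)cc3nc4ccccc4nc3c2C12C(=O)N(Cc1cnnn1-c1ccccc1Br)c1ccccc12`: 27400 nM.

Among the measured compounds shown here, compound 3 is the only compound of the three with a number in this assay; the other two values sit at the limit of > 50000 nM in this assay, at which 2 of the 3 values shown sit. For that reason the step that the two limits leave unreadable from compound 1 to compound 2 cannot be read in either direction, and within the measured set there is no readable step at all.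

Compound 4 `N#CC1=C(N)Oc2c(N)cc3nc4ccccc4nc3c2C12C(=O)N(Cc1cnnn1-c1c(Cl)cc(Cl)cc1Cl)c1ccccc12` differs from compound 3 by 2,4,6-trichlorophenyl in place of 2-bromophenyl on an aromatic nitrogen. For the measured compounds named here, the single exchange on the same aromatic nitrogen within the measured compounds is the one from compound 1 to compound 2, and its size is not readable, so no measured step bears on the change to compound 4 in a usable way. Nothing in the numbers therefore supports an expectation of a step beyond the usual scatter in this assay in either direction.

On that basis compound 4 is expected to land near compound 3, with an estimate of 27000 nM in this assay and a range from 9000 nM to 80000 nM. The step this implies, a 1.0-fold lower number from compound 3 to compound 4 (0.01 log units; within the scatter), is expected to stay within the scatter.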

Compound 4, half-maximal inhibitory concentration: > 50000 nM
Compound 4: only a limit was reported (the forecaster's own chance of this, stated with the estimate: 35%); at least 1.8-fold (0.26 log units) between middle value and limit.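

In this assay, compound 4 gives > 50000 nM, which is a limit of the assay. Among the compounds shown here, the exchange of 2-bromophenyl for 2,4,6-trichlorophenyl on the aromatic nitrogen gives an at least 1.8-fold higher number from compound 3 to compound 4 (0.26 log units; that floor lies within the scatter), the first step at this position with any readable size, since the only earlier exchange here could not be read. Its floor lies within the scatter, so the result does not establish a real difference between the two aryl groups, and it shows only that the 2,4,6-trichlorophenyl compound gave no number in this assay, leaving the series gathered at one limit: the limit of > 50000 nM in this assay, at which 3 of the 4 values shown sit.

For the compounds shown here, open is whether the aryl group on this aromatic nitrogen can move the value at all, since compound 3 remains the only compound with a number and the true size of the step to compound 4 is unknown. An unsubstituted phenyl, a phenyl carrying a methoxy group or a carboxylic acid, or a simple alkyl chain on the same nitrogen of the core of compound 3 would each test this position, and the compounds shown say nothing about any of them.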